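This account rests on a few compounds, and the source may have more. Where it says the series, first, only, none or still open, it means among the compounds named here.

Compound 2 `Cc1ccc2ccc(-c3cc(C#N)cc(C#N)c3)cc2n1` and compound 1 `Cc1ccc2ccc(-c3cc(Cl)cc(C#N)c3)cc2n1` share a core and differ only on the pendant aromatic ring. In a functional assay on CHO cells for inhibition of metabotropic glutamate receptor 5 (Rattus norvegicus), read by FLIPR and calcium flux (on this read-out higher numbers stand for weaker inhibition and lower numbers for stronger inhibition), compound 1 gives 1.4 nM, and compound 2 gives 2 nM; the step of a 1.4-fold higher number from compound 1 to compound 2 (0.15 log units; within the scatter) is within the scatter, so compound 2 stands on the higher of the two numbers without being distinguishable from compound 1. Compound 3 `COc1cc(C#N)cc(-c2ccc3ccc(C)nc3c2)c1` carries the change (methoxy in place of cyano on an aromatic carbon). Among the measured compounds shown here, only the step from compound 1 to compound 2 bears on it, and it was small, so a modest rise is expected, a 2.5-fold higher number from compound 2 to compound 3 (0.40 log units; beyond the scatter). Compound 3 is thus estimated at 5 nM, between 1.5 nM and 20 nM.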

Compound 3, half-maximal inhibitory concentration: 2.4 nM
Beside the measured number, compound 3's estimate is 2.1-fold (0.32 log units) above it, and the stated range covers the measured number.
By their numbers in this assay, from the lowest: compounds 1, 2 and 3 (each within the scatter of the next).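

In this assay, methoxy at this position cannot be told apart from either earlier group (a 1.2-fold higher number from compound 2 to compound 3 (0.08 log units; within the scatter); a 1.7-fold higher number from compound 1 to compound 3 (0.23 log units; within the scatter)). Cyano, chloro and now methoxy, which brings oxygen rather than nitrogen or chlorine onto the ring, all give numbers within the scatter of one another, so this change leaves the number in place. Nothing available explains why these groups match.

Going by these compounds, whether an amine, a carboxylic acid or a longer chain at this position would also hold the number stays open. So does whether the same change would behave alike on a different core.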